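Ethoxy in place of 4-nitrophenyl on a carbonyl carbon

The source may report more compounds than this note shows. Statements on the series, on what has been measured and on what is new or still open speak of the compounds shown alone.

In a functional assay on RPMI-8226 cells (Homo sapiens) for cytotoxicity, read by fluorescence, with a stated time of 72 h (on this read-out lower numbers stand for stronger inhibition and higher numbers for weaker inhibition), compound 1 (`Nc1n[nH]c(N)c1/N=N/c1ccncc1`) gives 6200 nM as its half-maximal inhibitory concentration. Compound 2 (`Nc1nn(C(=O)c2ccc([N+](=O)[O-])cc2)c(N)c1/N=N/c1ccc(O)cc1`) gives > 100000 nM as a limit of the assay and not as a number. Compared with compound 2, compound 3 (`CCOC(=O)n1nc(N)c(/N=N/c2ccc(O)cc2)c1N`) has ethoxy in place of 4-nitrophenyl on a carbonyl carbon. For the measured compounds named here, no measured step covers this change in this assay, so only a modest shift towards stronger inhibition is expected, and the estimated change is an at least 2.5-fold lower number from compound 2 to compound 3 (0.39 log units; beyond the scatter) in that direction. For compound 3 the expected value is 40000 nM with an estimated range from 8000 nM to 100000 nM in this measurement.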

Compound 3, half-maximal inhibitory concentration: > 100000 nM
Compound 3 was reported as a limit; the forecaster's own chance of this, stated with the estimate: 40%; middle value at least 2.5-fold (0.39 log units) away from the limit.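

No step can be read from compound 2 to compound 3, because both values are limits and not numbers: the limit of > 100000 nM in this assay, at which 2 of the 3 values shown sit.

The compounds shown leave open how far ethoxy in place of 4-nitrophenyl on a carbonyl carbon shifts inhibition.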